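Trimming the diol side chain of compound 2

The source may hold more compounds than are shown below. What is called first, only, known or untested is meant among the compounds shown, and "the series" means these compounds.

Within the data shown here, compound 2 `Cn1ncc(Cl)c1-c1cc(C(=O)N[C@@H]2CN[C@H](CC(O)CO)C[C@H]2c2ccc(F)c(F)c2)oc1Cl` gives the highest of the two numbers so far: in an assay for inhibition of RAC-alpha serine/threonine-protein kinase (Homo sapiens), read by HTRF, with a stated time of 1 h (on this read-out lower numbers stand for stronger inhibition and higher numbers for weaker inhibition), compound 2 gives 3.31 nM, while compound 1 `Cn1ncc(Cl)c1-c1cc(C(=O)N[C@@H]2CN[C@H](CCNS(C)(=O)=O)C[C@H]2c2ccc(F)c(F)c2)oc1Cl` gives 3.29 nM. Among the measured compounds shown here, the only step recorded, a 1.0-fold higher number from compound 1 to compound 2 (0.00 log units; within the scatter), exchanged the chain end without effect. Compound 3 `Cn1ncc(Cl)c1-c1cc(C(=O)N[C@@H]2CN[C@H](CCO)C[C@H]2c2ccc(F)c(F)c2)oc1Cl` differs from compound 2 by hydrogen in place of hydroxymethyl on a saturated chain carbon bound to an oxygen on a saturated carbon and a saturated chain carbon. That step touches the same chain end that the step from compound 1 to compound 2 showed to be tolerant, so no change beyond the scatter is expected, a 1.2-fold higher number from compound 2 to compound 3 (0.08 log units; within the scatter). Compound 3 is therefore estimated at 4 nM, within 1.5 nM to 11 nM.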

Compound 3, half-maximal inhibitory concentration: 0.98 nM
Compound 3: the middle estimate sits 4.1-fold (0.61 log units) above what was measured; the whole stated range lies above it.
By their numbers in this assay, from the lowest: compound 3; then compounds 1 and 2 (each within the scatter of the next).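

In this assay, the chain end proved less tolerant than the first pair suggested: hydrogen in place of hydroxymethyl gave a 3.4-fold lower number from compound 2 to compound 3 (0.53 log units; beyond the scatter) and left a 2-hydroxyethyl chain. Hydroxy in place of methanesulfonamido gave a 3.4-fold lower number from compound 1 to compound 3 (0.53 log units; beyond the scatter) by the same measure, so both other chain ends stand behind 2-hydroxyethyl. No evidence here explains this difference.

The compounds shown leave open whether the terminal hydroxy itself is needed. From the compounds shown here alone, how an amine, a carboxylic acid or a longer chain would compare at this chain end also remains open.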